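Methoxy in place of nitro on the shared core

A few compounds are considered here, and "the series" means these few. Any claim that something is new, unique, unknown or untested is made for them only; others in the source may bear on it.

For the measured compounds named here, compound 2 `O=[N+]([O-])c1ccc(/C=N/NC(=S)Nc2nc3ccc(Cl)cc3s2)cc1` gives 4.68 in a physicochemical assay for lipophilicity, in phosphate buffer, measured as octanol-water partition (on this read-out higher numbers stand for higher lipophilicity and lower numbers for lower lipophilicity), the lowest of the two numbers so far. Its nearest neighbour is compound 1 `S=C(N/N=C/c1ccc(Cl)cc1)Nc1nc2ccc(Cl)cc2s1`, which in this assay gives 5.52. Going by the values given here, the one measured step, nitro in place of chloro on an aromatic carbon, went a number 0.84 log units lower from compound 1 to compound 2 (beyond the scatter).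

Compound 3 `COc1ccc(/C=N/NC(=S)Nc2nc3ccc(Cl)cc3s2)cc1` differs from compound 2 by methoxy in place of nitro on an aromatic carbon. The step from compound 1 to compound 2 is the only one that bears on this change, and it touches the same aromatic carbon, though with a different group entering. Since that step moved the number downward beyond the scatter when nitro arrived, its departure is expected to move the number modestly back upward, by a number 0.27 log units higher from compound 2 to compound 3 (within the scatter). Compound 3 is therefore estimated at 4.95 in this assay, with a range from 4.5 to 5.4.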

Compound 3, partition coefficient: 5.16
The estimate for compound 3 lay 0.21 log units below the measured number; measured number inside the range.
By their numbers in this assay, from the lowest: compound 2; then compound 3; then compound 1.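

At this aromatic carbon, para to a large group, this assay now separates three groups rather than two: methoxy in place of nitro gives a number 0.48 log units higher from compound 2 to compound 3 (beyond the scatter), and methoxy in place of chloro gives a number 0.36 log units lower from compound 1 to compound 3 (beyond the scatter). For the compounds shown here, both steps are beyond the scatter, so compound 3 stands clearly apart from both neighbours, with methoxy falling between nitro and chloro, an order that the single earlier step could not reveal. Nothing measured here explains this order.

On these data alone, whether an amine, a carboxylic acid or a longer chain such as propoxy at the same carbon would fall inside the span of these three compounds or outside it remains open. So does whether the order of nitro, methoxy and chloro would hold with the same groups elsewhere on the ring.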